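Thiophen-2-yl in place of 4-methoxyphenyl on a carbonyl carbon

A few compounds are considered here, and "the series" means these few. Any claim that something is new, unique, unknown or untested is made for them only; others in the source may bear on it.

For the measured compounds named here, in a functional assay on MCF7 cells (Homo sapiens) for inhibition, read by MTT assay, with a stated time of 48 h (on this read-out lower numbers stand for stronger inhibition and higher numbers for weaker inhibition), compound 1 `COc1ccc(C(=O)C=CNc2cc(-c3ccccc3)nn2-c2ccccc2)cc1` gives 1290 nM, the lowest of the three numbers so far. Compound 3 `Cc1ccc(-c2ccnc3c2c(-c2ccccc2)nn3-c2ccccc2)cc1` gives 5590 nM and compound 2 `Clc1ccc(-c2ccnc3c2c(-c2ccccc2)nn3-c2ccccc2)cc1` gives 61100 nM, both clearly higher than compound 1 beyond the usual scatter.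

Compound 4 `O=C(C=CNc1cc(-c2ccccc2)nn1-c1ccccc1)c1cccs1` has not yet been measured. It differs from compound 1 in one place, with thiophen-2-yl in place of 4-methoxyphenyl on a carbonyl carbon.

Going by the values given here, the only measured step is an 11-fold lower number from compound 2 to compound 3 (1.04 log units; beyond the scatter), with methyl in place of chloro on an aromatic carbon. Among the compounds with values here, it is large, but it lies on a different core and at a different place, so it shows only that one swap can move these numbers far. Within the data shown here, no measured step touches this carbonyl carbon.

Compound 1 already has the lowest number at 1290 nM, so a rise seems likelier than a further fall. The expected change in this assay is moderate and upward, a 2.3-fold higher number from compound 1 to compound 4 (0.37 log units; beyond the scatter). For compound 4 the estimated value is 3000 nM, with an expected range from 700 nM to 12000 nM.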

Compound 4, half-maximal inhibitory concentration: 15400 nM
Beside the measured number, compound 4's estimate is 5.1-fold (0.71 log units) below it, and the stated range ends below it.
By their numbers in this assay, from the lowest: compound 1; then compound 3; then compound 4; then compound 2.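

For the compounds shown here, the group on this carbonyl carbon clearly matters: in this assay, thiophen-2-yl in place of 4-methoxyphenyl gives a 12-fold higher number from compound 1 to compound 4 (1.08 log units; beyond the scatter), the first measured step at this position, and a large one. This one swap changes several things at once, replacing a six-membered aromatic ring of carbon only, with its methoxy group, by a smaller five-membered aromatic ring that holds sulfur, so the step cannot be credited to any one of these differences. No measurement shown here explains why the number rises.

The compounds shown leave open whether the methoxy group or the ring itself accounts for the step, a question that plain phenyl on this carbonyl carbon could help settle. They also leave open how a non-aromatic group such as cyclohexyl would read at this position.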